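Phenyl replaces 1-phenylethyl on the piperazine-type ring nitrogen

A few compounds are considered here, and "the series" means these few. Any claim that something is new, unique, unknown or untested is made for them only; others in the source may bear on it.

Measured so far:
compound 1 `CCCn1c(=O)[nH]c2nc(-c3ccc(S(=O)(=O)N4CCN(c5ccc(Br)cc5)CC4)cc3)[nH]c2c1=O`, 0.0835 nM
compound 2 `CCCn1c(=O)[nH]c2nc(-c3ccc(S(=O)(=O)N4CCN(C(C)c5ccccc5)CC4)cc3)[nH]c2c1=O`, 8.34 nM

Of the compounds shown here, two have been measured in an assay on CHO cells for displacement of a labelled ligand from adenosine receptor A2b (Homo sapiens), read by scintillation counting, with a stated time of 75 min, in the presence of a further agent that is not named here; a lower number here means a stronger inhibitor, a higher number a weaker inhibitor. Compound 1 `CCCn1c(=O)[nH]c2nc(-c3ccc(S(=O)(=O)N4CCN(c5ccc(Br)cc5)CC4)cc3)[nH]c2c1=O` gives 0.0835 nM, and compound 2 `CCCn1c(=O)[nH]c2nc(-c3ccc(S(=O)(=O)N4CCN(C(C)c5ccccc5)CC4)cc3)[nH]c2c1=O` gives 8.34 nM. Among the compounds with values here, compound 2 therefore stands at the higher of the two numbers, and its only neighbour is compound 1, with a 100-fold higher number from compound 1 to compound 2 (2.00 log units; beyond the scatter).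

Compound 3 `CCCn1c(=O)[nH]c2nc(-c3ccc(S(=O)(=O)N4CCN(c5ccccc5)CC4)cc3)[nH]c2c1=O` is not yet measured. It differs from compound 2 by phenyl in place of 1-phenylethyl on an amine nitrogen in a ring.

Within the data shown here, the one measured step that bears on this change is a 100-fold higher number from compound 1 to compound 2 (2.00 log units; beyond the scatter), where a six-membered aromatic ring of carbon only, bound directly to the ring nitrogen, was exchanged for 1-phenylethyl and the number rose a great deal. Compound 3 reverses most of that exchange: phenyl, like 4-bromophenyl, is a six-membered aromatic ring of carbon only on the ring nitrogen, though it lacks the bromine of compound 1. A large step back towards the lower number is therefore expected, a 21-fold lower number from compound 2 to compound 3 (1.32 log units; beyond the scatter), though not necessarily all the way to compound 1. Compound 3 is estimated at 0.4 nM, with a range from 0.08 nM to 2 nM.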

Compound 3, inhibition constant: 0.643 nM
Compound 3: middle estimate off by 1.6-fold (0.21 log units), on the low side, within the range that was stated.
By their numbers in this assay, from the lowest: compound 1; then compound 3; then compound 2.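

Phenyl in place of 1-phenylethyl on the amine nitrogen in a ring gives a 13-fold lower number from compound 2 to compound 3 (1.11 log units; beyond the scatter) in this assay, so a large part of the rise seen with 1-phenylethyl is recovered even without the bromo group of compound 1. The bromo group still matters in its own right: hydrogen in place of bromo on an aromatic carbon gives a 7.7-fold higher number from compound 1 to compound 3 (0.89 log units; beyond the scatter), a modest step that is nonetheless beyond the scatter, and it shows that the aromatic ring bound directly to the ring nitrogen and the bromo group on that ring each contribute separately to the low number of compound 1. Nothing measured here explains the size of either step.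

The compounds shown cannot tell whether the higher number of compound 2 goes with the branching methyl or with the single carbon link to the phenyl ring, a question that a benzyl group on the same nitrogen would help to separate. They also leave open whether bromo is particular in this series, or whether chloro, methoxy or an amine on that aromatic carbon would give a similar number.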